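The compounds below may be only part of what the source reports. "The series", "measured", "known", "first", "only" and "open" are said of these compounds alone.

Going by the values given here, compound 2 `O=C(Nc1cccc(S(=O)(=O)C2CCCC2)c1)c1cccnc1N1CCCCC1` holds the higher of the two values measured so far in a functional assay on OVCAR-3 cells (Homo sapiens) for antiproliferative activity; a lower number here means that less compound is needed, a higher number that more compound is needed for the effect: compound 2 gives 5030 nM, while compound 1 `O=C(Nc1cccc(S(=O)(=O)C2CCCC2)n1)c1ccc(NCCO)cc1N1CCC2(CC1)CC2` gives 117 nM. These two differ in more than one place, so their gap cannot be tied to a single change. Compound 3 `CC1(C)CCN(c2ncccc2C(=O)Nc2cccc(S(=O)(=O)C3CCCC3)c2)CC1` follows from compound 2 by one change: 4,4-dimethylpiperidin-1-yl in place of piperidin-1-yl on an aromatic carbon. Among the compounds with values here, no measured pair covers this kind of change in this assay, so a step of no more than the usual scatter is expected, direction open. For compound 3 the estimate in this assay is 3500 nM, within 1200 nM to 10000 nM, meaning an expected step of a 1.4-fold lower number from compound 2 to compound 3 (0.16 log units; within the scatter).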

Compound 3, half-maximal effective concentration: 2140 nM
Compound 3: middle estimate off by 1.6-fold (0.21 log units), on the high side; the range from low to high includes it.
By their numbers in this assay, from the lowest: compound 1; then compound 3; then compound 2.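

In this assay, going by these compounds alone, 4,4-dimethylpiperidin-1-yl in place of piperidin-1-yl gives a 2.4-fold lower number from compound 2 to compound 3 (0.37 log units; beyond the scatter), a modest step that is the first single-place change readable. This aromatic carbon next to the ring nitrogen therefore takes the larger group with no rise in the number. No measured data on the origin of this step are available.

Still open, going by these compounds, is how an amine or a carboxylic acid on the piperidine ring would move the number. On these data alone, whether the same step holds on the core of compound 1 also remains open.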